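Amide nitrogen substituent exchange on the shared core

The compounds below may be only part of what the source reports. "The series", "measured", "known", "first", "only" and "open" are said of these compounds alone.

Working notes on the series. In an assay on isolated protein for inhibition of Apoptosis regulator Bcl-2 (Homo sapiens), read by fluorescence polarization, with stated times of 5 min and 10 min (on this read-out higher numbers stand for weaker inhibition and lower numbers for stronger inhibition), compound 1 `CC(C)=CCCC1=CC[C@@H](C(=O)N(C)O)[C@H](c2ccccc2)C1` gives 2300 nM. Compound 3 `CC(C)=CCCC1=CC[C@H](C(=O)N(C)O)[C@@H](c2ccccc2)C1` is its mirror image and in this assay gives 2100 nM. The step of a 1.1-fold lower number from compound 1 to compound 3 (0.04 log units; within the scatter) is attributed to configuration alone because the fact that compounds 1 and 3 differ only in the configuration as drawn is the whole difference between the pair. Compound 2 `COC(=O)c1ccc(NC(=O)[C@@H]2CC=C(CCC=C(C)C)C[C@H]2c2ccccc2)cc1` is reported in this assay only as a limit, > 23000 nM. On the numbers shown compound 2 therefore stands at the weak end of the set, and the limit of > 23000 nM in this assay, at which 1 of the 3 values shown sits, means no number is available for it, only a bound.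

Compound 4 `COC(=O)CCNC(=O)[C@@H]1CC=C(CCC=C(C)C)C[C@H]1c1ccccc1` has not been measured. Relative to compound 2 the change is 2-(methoxycarbonyl)ethyl in place of 4-(methoxycarbonyl)phenyl on an amide-type nitrogen. For the measured compounds named here, none of the measured steps bears on an exchange at the amide nitrogen: the single measured step, a 1.1-fold lower number from compound 1 to compound 3 (0.04 log units; within the scatter), concerns configuration and lies within the scatter, and compound 2 itself gives only a limit from which no step can be sized. The expected outcome is therefore that compound 4 stays in the weak region, with a fair chance that this assay again reports only a limit. Compound 4 is estimated at 20000 nM, with a range from 5000 nM to 60000 nM. The step of an at least 1.1-fold lower number from compound 2 to compound 4 (0.06 log units; that floor lies within the scatter) is an estimate only, not a measured result.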

Compound 4, inhibition constant: > 23000 nM
Compound 4: no number, only a limit; the forecaster's own chance of this, stated with the estimate: 55%; at least 1.1-fold (0.06 log units) between middle value and limit.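

In this assay compound 4 gives > 23000 nM, which is a limit and not a number. For the compounds shown here, replacing hydroxy(methyl)amino on the carbonyl carbon with (2-(methoxycarbonyl)ethyl)amino gives an at least 10-fold higher number from compound 1 to compound 4 (1.00 log units; beyond the scatter), so this position now has a step beyond the scatter, where the earlier compounds offered only a step in configuration and a single limit. The exchange of 4-(methoxycarbonyl)phenyl for 2-(methoxycarbonyl)ethyl on the amide-type nitrogen removes the aromatic ring and still yields no number, and the step between the two limits cannot be read, so the two nitrogen substituents cannot be ranked: the limit of > 23000 nM in this assay, at which 2 of the 4 values shown sit.

The compounds shown do not tell whether the hydroxy or the methyl of the hydroxy(methyl)amino group carries the difference, a question that a plain methylamino amide or an unsubstituted hydroxyamino group on the same carbonyl carbon would address. They also leave open whether a carboxylic acid in place of the methyl ester, or a longer chain on the amide nitrogen, would bring a measurable number in this assay.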